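Swapping chloro for amino on a weak antiproliferative scaffold

A few compounds are considered here, and "the series" means these few. Any claim that something is new, unique, unknown or untested is made for them only; others in the source may bear on it.

Measured so far:
- compound 1, `Nc1nn(C(=O)Nc2ccc(Cc3ccccc3)cc2)c2ccccc12`: 31300 nM
- compound 2, `Nc1nn(C(=O)Nc2ccc(Cc3ccccc3)cc2)c2ccc(Cl)cc12`: 18800 nM

Two compounds share a core and differ only at one aromatic carbon. In a functional assay on OVCAR-5 cells (Homo sapiens) for antiproliferative activity, read by sulforhodamine B assay, with a stated time of 48 h (a higher number here means a weaker inhibitor of growth, a lower number a stronger inhibitor of growth), compound 1 gives 31300 nM, and compound 2 gives 18800 nM. Within the data shown here, the step of a 1.7-fold lower number from compound 1 to compound 2 (0.22 log units; within the scatter) is the only measured step, and it lies within the scatter, so the two numbers cannot be told apart with confidence. Compound 2 therefore stands on the lower of the two numbers, but only nominally; nothing separates it from compound 1 beyond measurement noise.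

Compound 3, `Nc1ccc2c(c1)c(N)nn2C(=O)Nc1ccc(Cc2ccccc2)cc1`, differs from compound 2 by amino in place of chloro on an aromatic carbon. Among the measured compounds shown here, no measured step shows what amino does at this position; the only comparison at hand, hydrogen against chloro, moved the number by an amount indistinguishable from scatter. With nothing pointing either way, no step beyond the scatter is expected in this assay for compound 3, and its estimate is set near the two measured values.

Compound 3 is thus expected to give about 25000 nM, with a likely range from 8000 nM to 80000 nM.

The expected step of a 1.3-fold higher number from compound 2 to compound 3 (0.12 log units; within the scatter) is an estimate and is within the scatter.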

Compound 3, concentration for 50% growth inhibition: 22600 nM
For compound 3 the middle estimate is 1.1-fold (0.04 log units) above the measured one; low and high end bracket the measured number.
By their numbers in this assay, from the lowest: compounds 2, 3 and 1 (each within the scatter of the next).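

In this assay, amino in place of chloro gives a 1.2-fold higher number from compound 2 to compound 3 (0.08 log units; within the scatter) on this aromatic carbon, and amino in place of hydrogen gives a 1.4-fold lower number from compound 1 to compound 3 (0.14 log units; within the scatter) at the same place. This carbon has now carried hydrogen, chloro and amino, and amino is the only one of the three that brings a hydrogen-bond donor and a hydrogen-bond acceptor, yet the three compounds cannot be told apart in this test of cell growth. Within this small set, then, neither swapping in a chlorine nor swapping in a nitrogen at this position gives a step that stands clear of the usual scatter, and nothing available explains that result.

The compounds shown leave open whether a carboxylic acid, a methoxy group or a longer chain on this same carbon would give a step beyond the scatter, or whether this position tolerates such groups just as it does these three. They also leave open whether a change elsewhere in the molecule, rather than on this carbon, would shift the number by more than the scatter.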